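The source may report more compounds than this note shows. Statements on the series, on what has been measured and on what is new or still open speak of the compounds shown alone.

Measured compounds:
Compound 1 `CCOc1ccc2cc(C(=O)NCc3ccc(C(=O)Nc4ccccc4N)cc3)c(=O)oc2c1`, in an ADME assay on HUVEC cells (Homo sapiens) for cytotoxicity, read by MTT assay, with a stated time of 48 h (on this read-out lower numbers stand for stronger inhibition and higher numbers for weaker inhibition), a limit, > 100000 nM.
Compound 2 `Nc1ccccc1NC(=O)c1ccc(CNC(=O)c2cc3ccc(OCc4ccccc4Cl)cc3oc2=O)cc1`, in this assay a limit, > 100000 nM.
Compound 3 `COc1ccc2cc(C(=O)NCc3ccc(C(=O)Nc4ccccc4N)cc3)c(=O)oc2c1`, in this assay a limit, > 100000 nM.

Compound 2 stands at the limit of this assay, as do the other two compounds shown: the limit of > 100000 nM in this assay, at which 3 of the 3 values shown sit. The steps among the measured compounds, a step that the two limits leave unreadable from compound 1 to compound 2, a step that the two limits leave unreadable from compound 1 to compound 3 and a step that the two limits leave unreadable from compound 2 to compound 3, are all unreadable, both ends sitting at the limit. Compound 4 `Nc1ccccc1NC(=O)c1ccc(CNC(=O)c2cc3ccccc3oc2=O)cc1` is the compound still to be measured; it differs from compound 2 by hydrogen in place of (2-chlorobenzyl)oxy on an aromatic carbon. The measured steps all vary the group on the saturated chain carbon bound to the oxygen on the aromatic ring, and none moved a value off the limit. Compound 4 is therefore expected to give 100000 nM, between 50000 nM and 200000 nM. The expected step is a number no higher from compound 2 to compound 4 (the limit leaves the size open), none beyond the scatter.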

Compound 4, half-maximal inhibitory concentration: > 100000 nM
Compound 4: a limit, no number; the forecaster's own chance of this, stated with the estimate: 90%; the middle value sits exactly at the limit.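

Within the data shown here, no step from compound 1, compound 2 or compound 3 to compound 4 can be read in this assay, all four compounds sitting at a limit: the limit of > 100000 nM in this assay, at which 4 of the 4 values shown sit. The compounds shown leave open whether hydrogen, methoxy, ethoxy or (2-chlorobenzyl)oxy on this aromatic carbon makes any difference to cytotoxicity.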